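Rearranged Side Chain on a Shared Core: Rat Exposure Expectation

The compounds below may be only part of what the source reports. "The series", "measured", "known", "first", "only" and "open" are said of these compounds alone.

Measured compounds:
compound 1 `Cc1nc(NCC2CC2)nc(N[C@@H]2C[C@H](C3(O)CC3)[C@@H](O)[C@H]2O)c1-c1nc2c(C)nccc2s1`, 772 ng.h/mL
compound 2 `Cc1nc(NCC2CCCCO2)nc(N[C@@H]2C[C@H](C(C)(C)O)[C@@H](O)[C@H]2O)c1-c1nc2c(C)nccc2s1`, 5230 ng.h/mL

In an ADME assay on the whole organism (plasma) for pharmacokinetics, with Rattus norvegicus as the target, with a stated time of 6 h, at a dose of 10 mg/kg by the oral route (on this read-out lower numbers stand for lower exposure and higher numbers for higher exposure at the dose given), compound 2 holds the higher of the two numbers; compound 1 sits well below it, and the gap between the two lies beyond the scatter. Compound 3 `COCC1(CNc2nc(C)c(-c3nc4c(C)nccc4s3)c(N[C@@H]3C[C@H](C(C)(C)O)[C@@H](O)[C@H]3O)n2)CC1` has the same atoms as compound 2, joined differently: 1-(methoxymethyl)cyclopropyl in place of oxan-2-yl on a saturated chain carbon bound to a nitrogen on an aromatic ring. For the measured compounds named here, no measured pair isolates this change, so the expectation rests on compound 2 alone. The step of a 1.6-fold lower number from compound 2 to compound 3 (0.21 log units; within the scatter) in this assay is expected to be small and downward, probably within the scatter. Compound 3 is estimated at 3200 ng.h/mL, with a range from 1000 ng.h/mL to 9000 ng.h/mL.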

Compound 3, area under the concentration-time curve: 370 ng.h/mL
The estimate for compound 3 lay 8.6-fold (0.94 log units) above the measured number; the measured number lies below the stated range.
By their numbers in this assay, from the lowest: compound 3; then compound 1; then compound 2.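

Joining the same atoms as 1-(methoxymethyl)cyclopropyl in place of oxan-2-yl gives a 14-fold lower number from compound 2 to compound 3 (1.15 log units; beyond the scatter) in this assay and so shows that this position, on a saturated chain carbon bound to a nitrogen on an aromatic ring, responds strongly to arrangement alone. The counts of hydrogen-bond donors and acceptors stay the same here, so those counts do not track exposure in this pair. No supporting measurement bears on why exposure falls.

As far as these compounds go, whether an amine ring such as piperidin-2-yl or an open methoxypropyl chain would hold the exposure of compound 2 remains open. Also open, from the compounds shown here alone, is whether this change would act alike alongside the 1-hydroxycyclopropyl group of compound 1.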